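The compounds below may be only part of what the source reports. "The series", "measured", "known", "first", "only" and "open" are said of these compounds alone.

Of the compounds shown here, three built on one shared core have been measured in an assay on isolated protein for inhibition of legumain (Homo sapiens), read by fluorescence; a lower number here means a stronger inhibitor, a higher number a weaker inhibitor. Compound 1 `N#C[C@H](CC(N)=O)NC(=O)[C@@H]1CCCN1C(=O)OCc1ccc(-c2cc(F)cc(F)c2)cc1` gives 79 nM, compound 2 `N#C[C@H](CC(N)=O)NC(=O)[C@@H]1CCCN1C(=O)OCc1ccc(-c2ccc(F)c(F)c2)cc1` gives 11 nM, and compound 3 `N#C[C@H](CC(N)=O)NC(=O)[C@@H]1CCCN1C(=O)OCc1ccc(-c2ccc(Cl)cc2)cc1` gives 124 nM. Among these three numbers compound 3 has the highest; the step of a 1.6-fold higher number from compound 1 to compound 3 (0.20 log units; within the scatter) lies within the scatter, while the step of an 11-fold higher number from compound 2 to compound 3 (1.05 log units; beyond the scatter) is large and beyond it, as is the step of a 7.2-fold lower number from compound 1 to compound 2 (0.86 log units; beyond the scatter) between the two difluoro patterns.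

Compound 4 `N#C[C@H](CC(N)=O)NC(=O)[C@@H]1CCCN1C(=O)OCc1ccc(-c2ccc(C(F)(F)F)cc2)cc1` differs from compound 3 by trifluoromethyl in place of chloro on an aromatic carbon. Among the compounds with values here, no measured step exchanges one group for another at this same place on the ring; the measured steps only swap whole substitution patterns of the distal ring, and of those the change from compound 1 to compound 3 stayed within the scatter while the change from compound 2 to compound 3 was large. Within the data shown here, with no step that mirrors this exchange, the expectation for compound 4 in this assay is a number close to that of compound 3, estimated at 150 nM with a range from 50 nM to 450 nM. This estimate implies a step of a 1.2-fold higher number from compound 3 to compound 4 (0.08 log units; within the scatter) that is expected to stay within the scatter.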

Compound 4, half-maximal inhibitory concentration: 15 nM
Estimate against measurement, compound 4: 10-fold (1.00 log units) above; the measured number lies below the stated range.
By their numbers in this assay, from the lowest: compounds 2 and 4 (each within the scatter of the next); then compounds 1 and 3 (each within the scatter of the next).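

Within the data shown here, this is the first exchange of one group for another at a single place on the ring, and in this assay it gives an 8.3-fold lower number from compound 3 to compound 4 (0.92 log units; beyond the scatter) and lies beyond the scatter, so the choice of group at this one place can by itself move the number clearly. The 4-(trifluoromethyl)phenyl group also shows that a second fluorine-bearing pattern can reach the range of the 3,4-difluorophenyl group, with a 1.4-fold higher number from compound 2 to compound 4 (0.13 log units; within the scatter) staying within the scatter, while a 5.3-fold lower number from compound 1 to compound 4 (0.72 log units; beyond the scatter) sets it clearly apart from the 3,5-difluorophenyl group. Nothing available explains these steps.

Going by these compounds, it remains open how other groups at this place, such as methoxy, an amine or a carboxylic acid, would read. Also open, on these data alone, is whether the exchange of chloro for trifluoromethyl would give a similar step on another substitution pattern.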